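Removing a Methyl from a Nitro-Thiazole Core: Solubility Outlook

A few compounds are considered here, and "the series" means these few. Any claim that something is new, unique, unknown or untested is made for them only; others in the source may bear on it.

Measured compounds:
- compound 1, `O=C(c1sc2c([N+](=O)[O-])cc(C(F)(F)F)cc2[n+]1[O-])N1CCCCC1`: 84700 nM
- compound 2, `Cc1c(C(F)(F)F)cc2nc(C3=N[C@H](C(=O)N4CCCC4)CO3)sc2c1[N+](=O)[O-]`: 12000 nM

In a physicochemical assay for solubility (a lower number here means a less soluble compound, a higher number a more soluble compound), compound 1 gives 84700 nM, and compound 2 gives 12000 nM. Compound 2 thus stands at the lower of the two numbers, with compound 1 the nearer neighbour at a gap that lies beyond the scatter of repeated measurements.

Compound 3, `O=C([C@@H]1COC(c2nc3cc(C(F)(F)F)cc([N+](=O)[O-])c3s2)=N1)N1CCCC1`, is the compound still to be measured. It differs from compound 2 in one place: hydrogen in place of methyl on an aromatic carbon.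

Within the data shown here, no step between two measured compounds is available that would show how this change plays out in this assay. The change is small, a single heavy atom, so only a modest movement is expected, most likely toward a higher number: the estimated step is a 1.7-fold higher number from compound 2 to compound 3 (0.22 log units; within the scatter), and this expected step lies within the usual scatter. For compound 3 the expected value in this assay is 20000 nM, with a range from 8000 nM to 50000 nM.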

Compound 3, solubility: 64600 nM
The estimate for compound 3 lay 3.2-fold (0.51 log units) below the measured number; measured number above the stated range.
By their numbers in this assay, from the lowest: compound 2; then compounds 3 and 1 (each within the scatter of the next).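

Among these compounds, with hydrogen in place of methyl on the aromatic carbon ortho to a nitro group and ortho to a trifluoromethyl group, this assay gives a 5.4-fold higher number from compound 2 to compound 3 (0.73 log units; beyond the scatter) and so provides the first single-place comparison in this set. It shows that this position is not silent: removing one carbon there moves the number beyond the scatter, although the two compounds are otherwise the same. Nothing available explains why the number moves at this position.

This single pair cannot show whether the step would have the same size or direction on a different core or with a different amide. It also leaves open how this assay would respond to another group on this aromatic carbon, such as a fluorine, a methoxy group or an amine.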